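The source may report more compounds than this note shows. Statements on the series, on what has been measured and on what is new or still open speak of the compounds shown alone.

Compound 1 `CNC(=O)c1cc(Oc2ccc(NC(=O)c3cc(-c4ccc(Cl)cc4)ncn3)cc2F)ccn1`: > 100000 nM
Compound 2 `CNC(=O)c1cc(Oc2ccc(NC(=O)c3nccc(-c4ccc(OC)cc4)n3)cc2F)ccn1`: 24300 nM

In a functional assay on PC-3 cells (Homo sapiens) for cytotoxicity, read by MTT assay, with a stated time of 72 h (on this read-out lower numbers stand for stronger inhibition and higher numbers for weaker inhibition), compound 1 stands at > 100000 nM, which is a limit of the assay and not a number. Compound 3 `CNC(=O)c1cc(Oc2ccc(NC(=O)c3cc(-c4ccc(OC)cc4)ncn3)cc2F)ccn1` has methoxy in place of chloro on an aromatic carbon, para to a large group, so that 4-chlorophenyl becomes 4-methoxyphenyl (methoxy in place of chloro on an aromatic carbon). The expectation rests on compound 2, which gives a measured 24300 nM. The expected change is towards stronger inhibition, with an estimated step of an at least 2.5-fold lower number from compound 1 to compound 3 (0.39 log units; beyond the scatter) whose size is uncertain. For compound 3, the estimated value is 40000 nM, with an expected range of 12000 nM to 100000 nM.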

Compound 3, half-maximal inhibitory concentration: 56200 nM
Compound 3: middle estimate off by 1.4-fold (0.15 log units), on the low side; low and high end bracket the measured number.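

In this assay, compound 1 gives > 100000 nM, which is a limit of the assay and not a number. Methoxy in place of chloro on this aromatic carbon gives a value that can be read as a number, with an at least 1.7-fold lower number from compound 1 to compound 3 (0.25 log units; that floor lies within the scatter). That step is only a floor, and its true size stays unknown because one end of it is a limit: the limit of > 100000 nM in this assay, at which 1 of the 3 values shown sits.

As far as these compounds go, whether an amine or a longer chain such as butoxy at this same place would give a lower number remains open. So does whether any group here could bring the number far below that of compound 3.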